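Cinnamamide series on the shared core: next aryl change

The source may report more compounds than this note shows. Statements on the series, on what has been measured and on what is new or still open speak of the compounds shown alone.

Measured so far in a functional assay on PC-3 cells (Homo sapiens) for cytotoxicity, read by MTT assay, with a stated time of 72 h; a higher number here means a weaker inhibitor, a lower number a stronger inhibitor:
compound 1, `COc1ccc(C(=O)c2cc(OC)c(OC)c(OC)c2)cc1NC(=O)/C=C/c1ccc(OC)c(OC)c1`, 7500 nM
compound 2, `COc1ccc(C(=O)c2cc(OC)c(OC)c(OC)c2)cc1NC(=O)/C=C/c1ccc(C(F)(F)F)cc1`, 3500 nM
compound 3, `COc1ccc(C(=O)c2cc(OC)c(OC)c(OC)c2)cc1NC(=O)/C=C/c1ccc(F)c(F)c1`, 8300 nM

Compound 3 gives the highest number of the three. Its nearest neighbour is compound 1, at a 1.1-fold higher number from compound 1 to compound 3 (0.04 log units; within the scatter), a gap inside the scatter, so no order can be read between these two. Compound 2 stands apart, at a 2.4-fold higher number from compound 2 to compound 3 (0.38 log units; beyond the scatter), a modest but real gap; in the other direction, a 2.1-fold lower number from compound 1 to compound 2 (0.33 log units; beyond the scatter) is of the same kind.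

Compound 4, `COc1ccc(C(=O)c2cc(OC)c(OC)c(OC)c2)cc1NC(=O)/C=C/c1ccc(N)cc1`, differs from compound 3 in one place: 4-aminophenyl in place of 3,4-difluorophenyl on a double-bonded chain carbon bound to a double-bonded chain carbon. Within the data shown here, no measured compound carries an aminophenyl group, so the step has no direct precedent. Among the measured compounds shown here, the steps that bear on it are the two aryl swaps at the same position: the exchange of a difluorophenyl for a dimethoxyphenyl left the number within scatter, while the exchange for a trifluoromethylphenyl moved it modestly. Three aryl groups span only a modest range, so a further aryl swap is expected to stay near compound 3, with no clear direction.

Compound 4 is therefore expected to lie close to compound 3, the estimated step being a 1.2-fold lower number from compound 3 to compound 4 (0.07 log units; within the scatter), within the scatter. The estimate for compound 4 is 7000 nM, with a range from 2500 nM to 20000 nM.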

Compound 4, half-maximal inhibitory concentration: 15900 nM
Compound 4: the middle estimate sits 2.3-fold (0.36 log units) below what was measured, within the range that was stated.
By their numbers in this assay, from the lowest: compound 2; then compounds 1, 3 and 4 (each within the scatter of the next, the first and the last beyond it).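

In this assay the amino in place of trifluoromethyl exchange gives a 4.5-fold higher number from compound 2 to compound 4 (0.66 log units; beyond the scatter) and is the largest step shown at this position, so the range of the aryl group is wider than the first three compounds suggested, and compound 2 remains the strongest inhibitor of the four. The picture against the other two aryl groups is uneven: the change from 3,4-dimethoxyphenyl gives a 2.1-fold higher number from compound 1 to compound 4 (0.33 log units; beyond the scatter) and lies beyond the scatter, whereas the change from 3,4-difluorophenyl gives a 1.9-fold higher number from compound 3 to compound 4 (0.28 log units; within the scatter) and lies within it, so no order can be read between those two, and compound 3 and compound 4 stay together at the weak end with compound 1 close by. No measurement is available to explain why these aryl groups separate as they do.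

As far as these compounds go, whether the trifluoromethyl group is singular at this place or one of several groups that give a lower number remains open, since a nitrile, a chlorine or a carboxylic acid on the same phenyl ring would test this. Also open, from the compounds shown here alone, is how an acetamide or a dimethylamino group would compare with the free amine of compound 4.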